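Replacing the methoxycyclohexyl amide with a pyridin-2-yl amide

A few compounds are considered here, and "the series" means these few. Any claim that something is new, unique, unknown or untested is made for them only; others in the source may bear on it.

Measured so far:
compound 1 `COc1cc(OC)c(C(=O)Nc2c[nH]nc2C(=O)N[C@H]2CC[C@H](OC)CC2)c(OC)c1`: > 50000 nM, a limit of the measurement
compound 2 `COc1cccc(OC)c1C(=O)Nc1c[nH]nc1C(=O)N[C@H]1CC[C@H](OC)CC1`: 31000 nM
compound 3 `COc1cccc(OC)c1C(=O)Nc1c[nH]nc1C(=O)NC1CCN(Cc2ccccc2)C1`: 38000 nM

Three compounds sharing one core were tested in an ADME assay on MRC5 cells (Homo sapiens) for inhibition, with a stated time of 72 h; a higher number here means that more compound is needed for the effect, a lower number that less compound is needed. For compound 1 the result, > 50000 nM, is a limit of the measurement rather than a number. Compound 2 gives 31000 nM, the lowest of the two numbers shown. Compound 3 gives 38000 nM, which lies within the usual scatter of the value for compound 2, so the two cannot be ordered. Among the compounds with values here, the only measured step, an at least 1.6-fold lower number from compound 1 to compound 2 (0.20 log units; that floor lies within the scatter), is known just as a floor because compound 1 sits at the limit of > 50000 nM in this assay, at which 1 of the 3 values shown sits.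

Compound 4 `COc1cccc(OC)c1C(=O)Nc1c[nH]nc1C(=O)Nc1ccccn1` has not yet been measured. Its change from compound 2 is pyridin-2-yl in place of 4-methoxycyclohexyl on an amide-type nitrogen. No measured step touches the amide-type nitrogen, so nothing shown speaks directly to this change. The two measured compounds that carry different groups at that nitrogen, compound 2 and compound 3, give values within the scatter of each other. Compound 4 is therefore expected to show no step beyond the scatter, a 1.1-fold higher number from compound 2 to compound 4 (0.05 log units; within the scatter), with the chance that the assay again reports only a limit. The estimate for compound 4 is 35000 nM, expected to fall between 12000 nM and 100000 nM.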

Compound 4, half-maximal effective concentration: > 50000 nM
Compound 4: only a limit was reported; the forecaster's own chance of this, stated with the estimate: 35%; at least 1.4-fold (0.15 log units) between middle value and limit.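

Compound 4 is the first compound shown with an aromatic ring directly on the amide-type nitrogen, and in this assay it yields only a limit, not a number. Replacing 4-methoxycyclohexyl with pyridin-2-yl can therefore be read only as an at least 1.6-fold higher number from compound 2 to compound 4 (0.20 log units; that floor lies within the scatter); the real step may be larger, but the result gives only this floor and does not show how far it goes. What is new is that a change on this nitrogen, and not only one on the aromatic carbon of the earlier step, has now reached the limit of the measurement: the limit of > 50000 nM in this assay, at which 2 of the 4 values shown sit.

As far as these compounds go, whether pyridin-2-yl truly raises the number beyond the usual scatter stays open, and so does the question of whether the nitrogen within that ring matters or the aromatic ring alone is enough. From the compounds shown here alone, how a plain phenyl ring or a hydroxyethyl chain on the same amide-type nitrogen would read in this assay also remains open, and either could help to separate those two possibilities.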